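The source may hold more compounds than are shown below. What is called first, only, known or untested is meant among the compounds shown, and "the series" means these compounds.

Three compounds share the same core and differ only in the group sitting on an aromatic carbon of a six-membered aromatic ring of carbon only. Compound 1 `CC(=O)c1ccc(OCc2cccc(C)c2)cc1` carries a methyl there, compound 2 `CC(=O)c1ccc(OCc2cccc(F)c2)cc1` a fluoro, and compound 3 `CC(=O)c1ccc(OCc2cccc(C(F)(F)F)c2)cc1` a trifluoromethyl. In an assay on isolated protein for inhibition of Amine oxidase [flavin-containing] A (Homo sapiens), read by Amplex Red, with a stated time of 15 min, tested at 100 uM (on this read-out lower numbers stand for less inhibition and higher numbers for more inhibition at the one concentration tested (going by the name of the read-out)), compound 1 gives 32.3%, compound 2 gives 48.4% and compound 3 gives 48.9%, the largest of the three numbers, though compound 2 sits within the scatter of it. The two steps away from the methyl, a number 16.1 percentage points higher from compound 1 to compound 2 (beyond the scatter) and a number 16.6 percentage points higher from compound 1 to compound 3 (beyond the scatter), lie beyond the scatter, whereas a number 0.5 percentage points higher from compound 2 to compound 3 (within the scatter) does not. Compound 4 `CC(=O)c1ccc(OCc2cccc(Br)c2)cc1` has not yet been measured. The change from compound 3 is bromo in place of trifluoromethyl on an aromatic carbon. The step that bears most on it is a number 0.5 percentage points higher from compound 2 to compound 3 (within the scatter), which shows that two different groups at this place gave numbers within the scatter of each other. For compound 4 in this assay a step of a number 1.1 percentage points higher from compound 3 to compound 4 (within the scatter) is therefore expected, that is, none beyond the scatter. The estimate for compound 4 is 50%, ranging from 35% to 65%.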

Compound 4, a percentage reported as inhibition, at one concentration (the size of the read-out at that concentration, not a potency): 48.3%
Estimate against measurement, compound 4: 1.7 percentage points above; low and high end bracket the measured number.
By their numbers in this assay, from the lowest: compound 1; then compounds 4, 2 and 3 (each within the scatter of the next).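

In this assay, bromo is the third group at this place whose number cannot be told apart from the others, with a number 0.6 percentage points lower from compound 3 to compound 4 (within the scatter) and a number 0.1 percentage points lower from compound 2 to compound 4 (within the scatter), even though bromo enters as 1 heavy atom and trifluoromethyl leaves with 4 heavy atoms. Methyl remains the only one of the four groups set apart, with a number 16 percentage points higher from compound 1 to compound 4 (beyond the scatter), so fluoro, trifluoromethyl and bromo now form a cluster of three with methyl as the exception. Nothing measured here explains why these three groups cluster or why methyl stands apart.

As far as these compounds go, whether an amine, a hydroxyl or a carboxylic acid at this place would join the cluster or fall nearer methyl remains open. A reading at one concentration also leaves open whether compound 2, compound 3 and compound 4 would still match at other concentrations.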